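This account rests on a few compounds, and the source may have more. Where it says the series, first, only, none or still open, it means among the compounds named here.

Working notes on the series. Compound 1 `COc1ccc(-c2cccc(S(=O)(=O)N3CCC(N4CCC(C)CC4)CC3)c2)cc1` is the anchor: in a functional assay on DLD-1 cells (Homo sapiens) for antiproliferative activity, read by CellTiter-Glo, with a stated time of 72 h (a lower number here means a stronger inhibitor, a higher number a weaker inhibitor), compound 1 gives 23 nM. Compound 2 `CC1CCN(C2CCN(S(=O)(=O)c3cccc(Cl)c3)CC2)CC1` has only a limit of the assay, > 5000 nM, and no number. Among the measured compounds shown here, the one measured step, an at least 210-fold higher number from compound 1 to compound 2 (2.33 log units; beyond the scatter), is the swap of chloro for 4-methoxyphenyl at the aromatic carbon; the limit at compound 2 is recorded as the limit of > 5000 nM in this assay, at which 1 of the 2 values shown sits, so the true size of that step is unknown beyond its floor.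

Compound 3 `CC1CCN(C2CCN(S(=O)(=O)c3cccc(-c4ccccc4C(F)(F)F)c3)CC2)CC1` differs from compound 2 by 2-(trifluoromethyl)phenyl in place of chloro on an aromatic carbon. This is the reverse of the measured step in kind, an aryl ring entering where chloro stood, so a large gain in this assay is expected, with the direction set by the step from compound 1 to compound 2. The aryl is not the same as in compound 1, so the expected step of an at least 83-fold lower number from compound 2 to compound 3 (1.92 log units; beyond the scatter) is taken as somewhat smaller than the measured one. For compound 3 the estimated value is 60 nM, range 15 nM to 400 nM.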

Compound 3, half-maximal inhibitory concentration: 10 nM
Beside the measured number, compound 3's estimate is 6.0-fold (0.78 log units) above it; measured number outside the range, below it.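

In this assay, a second aryl group at this aromatic carbon also carries the series away from the chloro compound, an at least 500-fold lower number from compound 2 to compound 3 (2.69 log units; beyond the scatter), so the gain is not tied to 4-methoxyphenyl alone. Exchanging one aryl group for the other moves the number far less, a 2.3-fold lower number from compound 1 to compound 3 (0.36 log units; beyond the scatter), a modest step that is still beyond the scatter, so this position accepts 2-(trifluoromethyl)phenyl as well as 4-methoxyphenyl. The step from the chloro compound remains a floor and not a measured size: the limit of > 5000 nM in this assay, at which 1 of the 3 values shown sits.

On these data alone, what the two aryl groups contribute through their own substituents stays open, and an unsubstituted phenyl would separate that from the ring itself. As far as these compounds go, whether the ring must be aromatic also stays open, and a cyclohexyl or a pyridine ring at this carbon would test it.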